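A Sulfamoylbenzyl Analogue and Its Expected Cell Tolerance

A few compounds are considered here, and "the series" means these few. Any claim that something is new, unique, unknown or untested is made for them only; others in the source may bear on it.

Compound 3 `CCOC(=O)c1cnc(N2CCN(Cc3cccc([N+](=O)[O-])c3)CC2)nc1Oc1c(C)cc(-c2ccc(C#N)cc2)cc1C` is one of three compounds on a shared core that differ only in the substituent on a saturated chain carbon bound to an amine nitrogen in a ring. In an ADME assay on MT4 cells (Homo sapiens) for cytotoxicity, read by MTT assay, with a stated time of 4 days (a higher number here means that more compound is tolerated, a lower number that less compound is tolerated), compound 3 gives > 125000 nM, which is a limit of the assay and not a number. Compound 1 `CCOC(=O)c1cnc(N2CCN(Cc3ccc(F)cc3)CC2)nc1Oc1c(C)cc(-c2ccc(C#N)cc2)cc1C` gives > 117000 nM in this assay, also a limit. Compound 2 `CCOC(=O)c1cnc(N2CCN(Cc3ccccc3Br)CC2)nc1Oc1c(C)cc(-c2ccc(C#N)cc2)cc1C` gives > 125000 nM in this assay, a limit as well. Accordingly the steps a step that the two limits leave unreadable from compound 1 to compound 2, a step that the two limits leave unreadable from compound 1 to compound 3 and a step that the two limits leave unreadable from compound 2 to compound 3 cannot be sized; all that is known is the limit of > 117000 nM in this assay, at which 1 of the 3 values shown sits, and (the limit of > 125000 nM in this assay, at which 2 of the 3 values shown sit).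

Compound 4 `CCOC(=O)c1cnc(N2CCN(Cc3ccc(S(N)(=O)=O)cc3)CC2)nc1Oc1c(C)cc(-c2ccc(C#N)cc2)cc1C` carries the change (4-sulfamoylphenyl in place of 3-nitrophenyl on a saturated chain carbon bound to an amine nitrogen in a ring). Going by the values given here, because every measured value in this assay sits at the limit of > 117000 nM in this assay, at which 1 of the 3 values shown sits, or (the limit of > 125000 nM in this assay, at which 2 of the 3 values shown sit), none of the measured steps shows a readable effect of varying this group, and no direction for compound 4 can be drawn from them. The step of a number no higher from compound 3 to compound 4 (the limit leaves the size open) is therefore expected to be no more than scatter, with compound 4 most likely returning another limit. Compound 4 is estimated at 125000 nM in this assay, within a range from 60000 nM to 250000 nM.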

Compound 4, half-maximal cytotoxic concentration: >= 7930 nM
Compound 4 ended at the assay's limit (the forecaster's own chance of this, stated with the estimate: 80%); the middle value lies beyond the limit too.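

In this assay compound 4 gives >= 7930 nM, which is a limit of the assay and not a number. The steps to compound 4 from compound 1, compound 2 and compound 3 therefore cannot be read. The compounds shown leave open where the true value of each lies, and whether varying this group changes cell tolerance at all.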